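From an acetamidophenyl amide to an aminophenylamino carbonyl

The compounds below may be only part of what the source reports. "The series", "measured", "known", "first", "only" and "open" are said of these compounds alone.

In a functional assay on NCI-H460 cells (Homo sapiens) for positive allosteric modulation, read by MTT assay, with stated times of 2 h and 72 h, tested at 10 uM (on this read-out higher numbers stand for weaker inhibition and lower numbers for stronger inhibition), compound 2 `COc1cccc(-n2nnc(-c3ccccc3NC(=O)c3ccc(NC(C)=O)cc3)n2)c1` gives 520 nM, the highest of the three numbers measured, against compound 3 `COc1ccc(NC(=O)Nc2ccccc2-c2nnn(-c3ccc(OC)cc3)n2)cc1` at 211 nM and compound 1 `CCCc1ccc(C(=O)Nc2ccccc2-c2nnn(-c3cccc(OC)c3)n2)cc1` at 121 nM. Compound 4 `COc1cccc(-n2nnc(-c3ccccc3NC(=O)Nc3ccc(N)cc3)n2)c1` changes the group on the carbonyl carbon: (4-aminophenyl)amino in place of 4-acetamidophenyl on a carbonyl carbon. Within the data shown here, only one measured step bears on the acetamido group, namely a 4.3-fold higher number from compound 1 to compound 2 (0.63 log units; beyond the scatter). Compound 4 loses that group, so part of this step may be reversed. Compound 3 also has a nitrogen-linked aryl group on the carbonyl carbon and gives 211 nM, though it differs elsewhere too. Among the measured compounds shown here, no measured compound carries a free amino group, so the evidence is thin. A small move to a lower number is expected in this assay, a 2.2-fold lower number from compound 2 to compound 4 (0.34 log units; beyond the scatter). For compound 4 the estimate is 240 nM, with an expected range of 80 nM to 700 nM.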

Compound 4, half-maximal inhibitory concentration: 176 nM
For compound 4 the middle estimate is 1.4-fold (0.13 log units) above the measured one, within the range that was stated.
By their numbers in this assay, from the lowest: compounds 1, 4 and 3 (each within the scatter of the next); then compound 2.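

In this assay, (4-aminophenyl)amino in place of 4-acetamidophenyl on a carbonyl carbon gives a 3.0-fold lower number from compound 2 to compound 4 (0.47 log units; beyond the scatter), showing that the high number of compound 2 is not shared by every polar-free reading of this position.

Correction: that sentence used a wording the data do not support, so this version replaces it.

In this assay, (4-aminophenyl)amino in place of 4-acetamidophenyl on a carbonyl carbon gives a 3.0-fold lower number from compound 2 to compound 4 (0.47 log units; beyond the scatter), so the number at this position can be brought down without the propyl group. Against 4-propylphenyl, the same group gives a 1.5-fold higher number from compound 1 to compound 4 (0.16 log units; within the scatter), and these two groups on the carbonyl carbon cannot be told apart here. Nothing available accounts for either step. Still open, on these data alone, is whether the free amino group or the nitrogen link to the carbonyl carbon carries the step from compound 2, and how a dimethylamino group or a carboxylic acid in place of that amino group would read.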